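The compounds below may be only part of what the source reports. "The series", "measured", "known", "first", "only" and "open" are said of these compounds alone.

Measured compounds:
compound 1, `Cc1cccc(-n2nncc2CN2C(=O)C3(C(C#N)=C(N)Oc4c3c3nc5ccccc5nc3c3ccccc43)c3ccccc32)c1` — 39600 nM
compound 2, `N#CC1=C(N)Oc2c(c3nc4ccccc4nc3c3ccccc23)C12C(=O)N(Cc1cnnn1-c1ccccc1Cl)c1ccccc12` — 42600 nM
compound 3, `Cc1ccc(-n2nncc2CN2C(=O)C3(C(C#N)=C(N)Oc4c3c3nc5ccccc5nc3c3ccccc43)c3ccccc32)c(C)c1` — > 50000 nM

In a functional assay on A549 cells (Homo sapiens) for antiproliferative activity, read by MTT assay, with a stated time of 48 h (a higher number here means a weaker inhibitor, a lower number a stronger inhibitor), compound 1 gives 39600 nM. In this assay compound 2 gives 42600 nM. Compound 3 reaches only the limit of this assay, reported as > 50000 nM. Compound 1 thus holds the lowest of the two numbers, with compound 2 nearest to it at a 1.1-fold higher number from compound 1 to compound 2 (0.03 log units; within the scatter).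

Compound 4, `Cc1ccc(-n2nncc2CN2C(=O)C3(C(C#N)=C(N)Oc4c3c3nc5ccccc5nc3c3ccccc43)c3ccccc32)cc1Cl`, differs from compound 1 in one place: 3-chloro-4-methylphenyl in place of 3-methylphenyl on an aromatic nitrogen. Three measured steps change the same group on the same aromatic nitrogen: a 1.1-fold higher number from compound 1 to compound 2 (0.03 log units; within the scatter), an at least 1.2-fold higher number from compound 1 to compound 3 (0.10 log units; that floor lies within the scatter) and an at least 1.1-fold higher number from compound 2 to compound 3 (0.06 log units; that floor lies within the scatter). None of them moves beyond the scatter, and the two that end at compound 3 stop at the limit of > 50000 nM in this assay, at which 1 of the 3 values shown sits. The 3-chloro-4-methylphenyl group of compound 4 combines features of the groups in compound 2 and compound 3, and nothing in those steps points to a clear change in either direction. For compound 4 the step in this assay is therefore expected to be small or absent, with a real chance that the assay again reports only a limit. Compound 4 is estimated at 46000 nM, with a range from 25000 nM to 85000 nM. That estimate means an expected step of a 1.2-fold higher number from compound 1 to compound 4 (0.07 log units; within the scatter).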

Compound 4, half-maximal inhibitory concentration: > 50000 nM
Compound 4: a limit, no number; the forecaster's own chance of this, stated with the estimate: 35%; at least 1.0-fold (0.03 log units) between middle value and limit.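

The 3-chloro-4-methylphenyl group in place of 3-methylphenyl gives an at least 1.2-fold higher number from compound 1 to compound 4 (0.10 log units; that floor lies within the scatter), and in place of 2-chlorophenyl it gives an at least 1.1-fold higher number from compound 2 to compound 4 (0.06 log units; that floor lies within the scatter), so pairing a chlorine with a methyl on this phenyl ring yields no readable gain in this assay over the single-substituent groups of compound 1 and compound 2. The step between compound 3 and compound 4 cannot be read, since each of the two carries only a limit, and the position now has four substituted phenyl groups with no readable step beyond the scatter. For the series as shown, the limit has become a common result on this aromatic nitrogen: the limit of > 50000 nM in this assay, at which 2 of the 4 values shown sit.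

The compounds shown leave open how far compound 3 and compound 4 actually lie from compound 1 and compound 2, as their limits give only floors. They also leave open whether a group of another kind on this aromatic nitrogen, such as a phenyl ring bearing an amine or a carboxylic acid, or a longer alkyl chain in place of the phenyl ring, would move the number beyond the scatter.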